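Methylsulfanyl replacing fluoro: from compound 3 to compound 4

This account rests on a few compounds, and the source may have more. Where it says the series, first, only, none or still open, it means among the compounds named here.

Compound 1 `CN1CCCC(NC(=O)c2ccc(C(F)(F)F)cc2)(c2ccccc2)C1` tested in an assay on cells for inhibition of sodium- and chloride-dependent glycine transporter 1 (Homo sapiens) (a higher number here means that more compound is needed for the effect, a lower number that less compound is needed), gives > 10000 nM, a limit of the assay rather than a number. Compound 2 `CN1CCCC(NC(=O)c2ccc(C(F)(F)F)cc2C#N)(c2ccccc2)C1` likewise gives > 10000 nM, again a limit. Among the measured compounds shown here, compound 3 `CN1CCCC(NC(=O)c2ccc(C(F)(F)F)cc2F)(c2ccccc2)C1` gives 9900 nM, the only number among the three; the two other values sit at the limit of > 10000 nM in this assay, at which 2 of the 3 values shown sit. The steps a step that the two limits leave unreadable from compound 1 to compound 2, a number no higher from compound 1 to compound 3 (the limit leaves the size open) and a number no higher from compound 2 to compound 3 (the limit leaves the size open) therefore cannot be sized. Compound 4 `CSc1cc(C(F)(F)F)ccc1C(=O)NC1(c2ccccc2)CCCN(C)C1` differs from compound 3 by methylsulfanyl in place of fluoro on an aromatic carbon. For the measured compounds named here, none of the measured steps concerns a methylsulfanyl group, and all are unreadable, so no direction can be drawn from them. For compound 4 the estimated step is a 1.2-fold lower number from compound 3 to compound 4 (0.09 log units; within the scatter), none beyond the scatter. Compound 4 is thus expected to give 8000 nM, with a range from 2000 nM to 30000 nM, and a fair chance that only a limit is reported.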

Compound 4, half-maximal effective concentration: 67 nM
Beside the measured number, compound 4's estimate is 120-fold (2.08 log units) above it, and the stated range ends above it.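

Among the compounds shown here, the earlier steps among compounds 1, 2 and 3 cannot be read, so this is the first sized change at the position ortho to a large group. In this assay, methylsulfanyl gives a 150-fold lower number from compound 3 to compound 4 (2.17 log units; beyond the scatter), showing that this position can carry a large step. The same holds for the replacement of nitrile, with an at least 140-fold lower number from compound 2 to compound 4 (2.17 log units; beyond the scatter), and of hydrogen, with an at least 140-fold lower number from compound 1 to compound 4 (2.17 log units; beyond the scatter), though these two sizes rest on a limit: the limit of > 10000 nM in this assay, at which 2 of the 4 values shown sit.

From the compounds shown here alone, whether methoxy, ethylsulfanyl or methylsulfonyl at this position would give a similar step remains open. Also open, going by these compounds, is whether the step persists without the trifluoromethyl group.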